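A few compounds are considered here, and "the series" means these few. Any claim that something is new, unique, unknown or untested is made for them only; others in the source may bear on it.

Measured so far:
Compound 1, `CCSc1nc2c(cc(-c3ccc(Cl)cc3)n2-c2ccccc2)c(=N)s1`: 1%
Compound 2, `CCSc1nc2c(cc(-c3ccc(C)cc3)n2-c2ccccc2)c(=N)s1`: 0%
Compound 3, `CCC(C)Sc1nc2c(cc(-c3ccc(Cl)cc3)n2-c2ccccc2)c(=N)s1`: 2%

All three were run in a functional assay on the whole organism for inhibition, with Rattus norvegicus as the target, read by ELISA, with stated times of 30 min and 6 h, at a dose of 30 mg/kg by the oral route; a lower number here means less inhibition, a higher number more inhibition at the dose given (going by the name of the read-out). The three numbers sit close together; compound 3 shows the highest of them, but both of its steps to the others are within the scatter, so no order among them can be read from this assay.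

Compound 4, `CCC(C)Sc1nc2c(cc(-c3ccc(C)cc3)n2-c2ccccc2)c(=N)s1`, has not been measured. It stands to compound 3 as compound 2 stands to compound 1: the change is methyl in place of chloro on an aromatic carbon, and the earlier instance, (methyl in place of chloro on an aromatic carbon), gave a number 1 percentage points lower from compound 1 to compound 2 (within the scatter). The two cores differ by ethyl in place of hydrogen on a saturated chain carbon bound to a saturated chain carbon and a sulfur, which gave a number 1 percentage points higher from compound 1 to compound 3 (within the scatter).

For the measured compounds named here, with only one prior instance of the change, and that within the scatter, the step is expected to be about a number 1 percentage points lower from compound 3 to compound 4 (within the scatter), because a number 1 percentage points lower from compound 1 to compound 2 (within the scatter). Compound 4 is therefore estimated at 1%, with a range from -6% to 8%.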

Compound 4, a percentage reported as inhibition, in the whole organism at one dose (the size of the read-out at that dose, not a potency): 2%
Estimate against measurement, compound 4: 1 percentage points below; low and high end bracket the measured number.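

In this assay, methyl in place of chloro gives no change at the digits printed from compound 3 to compound 4 (within the scatter), and this agrees with the earlier instance on the other core: the same change on two cores in this assay, a number 1 percentage points lower (within the scatter) from compound 1 to compound 2 and no change at the digits printed (within the scatter) from compound 3 to compound 4, 1 percentage points apart, within the scatter of two such steps. Ethyl in place of hydrogen on the chain carbon bound to sulfur gives a number 2 percentage points higher from compound 2 to compound 4 (within the scatter), and this also agrees with its earlier instance: the same change on two cores in this assay, a number 1 percentage points higher (within the scatter) from compound 1 to compound 3 and a number 2 percentage points higher (within the scatter) from compound 2 to compound 4, 1 percentage points apart, within the scatter of two such steps. For the compounds shown here, all these steps lie within the scatter, so the agreement shows only that neither change separates the compounds at this dose; it does not show that a step of real size would carry from one core to another.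

The compounds shown leave open whether an amine or a carboxylic acid in place of chloro, or a longer chain on the sulfur, would give a step beyond the scatter. They also leave open how this series reads at any other dose.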